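Working notes: from compound 2 to compound 4

This account rests on a few compounds, and the source may have more. Where it says the series, first, only, none or still open, it means among the compounds named here.

Among the compounds with values here, in a functional assay on MDA-MB-231 cells (Homo sapiens) for cytotoxicity, read by MTT assay, with a stated time of 24 h (a lower number here means a stronger inhibitor, a higher number a weaker inhibitor), compound 2 `Cc1ccc(/C=C2\CN(C(=S)SCc3cn(Cc4ccc(F)cc4)nn3)C/C(=C\c3ccc(C)cc3)C2=O)cc1` gives 45600 nM, the only actual number in this small set. Compound 1 `COc1ccc(/C=C2\CN(C(=S)SCc3cn(Cc4ccc(F)cc4)nn3)C/C(=C\c3ccc(OC)cc3)C2=O)cc1` gives > 100000 nM, which is a limit of this assay and not a number. Compound 3 `COc1ccc(/C=C2\CN(Cc3cn(Cc4ccccc4Cl)nn3)C/C(=C\c3ccc(OC)cc3)C2=O)cc1` gives > 100000 nM, which is likewise only a limit.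

Compound 4 `Cc1ccc(/C=C2\CN(C(=S)SCc3cn(Cc4ccccc4Cl)nn3)C/C(=C\c3ccc(C)cc3)C2=O)cc1` keeps the shared core of compound 2 and changes in one place: 2-chlorophenyl in place of 4-fluorophenyl on a saturated chain carbon bound to an aromatic nitrogen. This puts 2-chlorophenyl in place of 4-fluorophenyl on a saturated chain carbon bound to an aromatic nitrogen, which also reads as 4-fluorobenzyl to 2-chlorobenzyl.

Within the data shown here, no measured pair isolates this change, so no direction is favoured and no shift beyond the scatter is expected in this assay. The expectation starts from compound 2 at 45600 nM. The expected step is a 1.2-fold higher number from compound 2 to compound 4 (0.08 log units; within the scatter). For compound 4 the estimated value is 55000 nM, with an expected range of 20000 nM to 100000 nM.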

Compound 4, half-maximal inhibitory concentration: 93200 nM
For compound 4 the middle estimate is 1.7-fold (0.23 log units) below the measured one; the range from low to high includes it.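

Within the data shown here, this is the only pair in the set that isolates a change at this position: in this assay, 2-chlorophenyl in place of 4-fluorophenyl on a saturated chain carbon bound to an aromatic nitrogen gives a 2.0-fold higher number from compound 2 to compound 4 (0.31 log units; beyond the scatter). The position therefore responds to this change, modestly and towards weaker inhibition, with compound 2 the stronger of the pair. The step is also read close to the top of the range the assay reports, which leaves little room for any further weakening to appear as a number: the limit of > 100000 nM in this assay, at which 2 of the 4 values shown sit.

The change from 4-fluorobenzyl to 2-chlorobenzyl alters the halogen and its place together, and the compounds shown do not separate the two, as 4-chlorobenzyl or 2-fluorobenzyl could. Also open, going by these compounds, is how an amine or a carboxylic acid on this phenyl would read in this assay.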